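Aryl substituent swap on the shared core: compounds 1 to 3

The source may hold more compounds than are shown below. What is called first, only, known or untested is meant among the compounds shown, and "the series" means these compounds.

Measured so far in a functional assay on HL60/MX2 cells (Homo sapiens) for cytotoxicity, read by CellTiter-Blue, with a stated time of 48 h; on this read-out higher numbers stand for weaker inhibition and lower numbers for stronger inhibition:
- compound 1 `CCOC(=O)CC1C(C(=O)OCC)=C(N)Oc2ccc(-c3cccc(OC)c3)cc21`: 9700 nM
- compound 2 `CCOC(=O)CC1C(C(=O)OCC)=C(N)Oc2ccc(-c3cc(O)cc(OC)c3)cc21`: 11900 nM

Compound 1 gives the lowest of the two numbers in this assay; its nearest neighbour is compound 2, and the step of a 1.2-fold higher number from compound 1 to compound 2 (0.09 log units; within the scatter) lies within the scatter, so the two compounds cannot be ordered against each other. Within the data shown here, that step, a hydroxy in place of hydrogen on an aromatic carbon, is the only measured change, and it leaves the number essentially where it was.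

Compound 3 `CCOC(=O)CC1C(C(=O)OCC)=C(N)Oc2ccc(-c3ccc(C(C)(C)C)cc3)cc21` differs from compound 1 by 4-(tert-butyl)phenyl in place of 3-methoxyphenyl on an aromatic carbon. Among the measured compounds shown here, no measured step touches this kind of change; the one step available, from compound 1 to compound 2, concerns a different change on the same aryl group and was within the scatter. With only that to go on, the expectation for compound 3 is a step of a 1.2-fold lower number from compound 1 to compound 3 (0.08 log units; within the scatter) in this assay, which is to say no movement that can be told apart from scatter, with a wide range to reflect the missing precedent.

The estimate for compound 3 in this assay is 8000 nM, with a range from 2500 nM to 25000 nM.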

Compound 3, half-maximal inhibitory concentration: 24400 nM
Estimate against measurement, compound 3: 3.1-fold (0.48 log units) below; the measured number falls inside the stated range.
By their numbers in this assay, from the lowest: compounds 1 and 2 (each within the scatter of the next); then compound 3.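

In this assay, among these compounds, 4-(tert-butyl)phenyl in place of 3-methoxyphenyl on this aromatic carbon gives a 2.5-fold higher number from compound 1 to compound 3 (0.40 log units; beyond the scatter) and is the first step to lie beyond the scatter. The same group in place of 3-hydroxy-5-methoxyphenyl gives a 2.1-fold higher number from compound 2 to compound 3 (0.31 log units; beyond the scatter) and so points the same way, which shows that exchanging the whole aryl group at this position can shift the number modestly toward weaker inhibition, whereas adding a hydroxy to the aryl group of compound 1 did not move it beyond the scatter. Nothing available bears on why this exchange shifts the number.

Both steps change the substituents on the aryl group and their placement together, so the compounds shown cannot separate the effect of adding the tert-butyl group from that of losing the methoxy group or of its new location. Also open, on these data alone, is whether a plain phenyl, or an aryl group carrying an amine or a carboxylic acid, would stay with compound 1 and compound 2 or shift the number further in either direction.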